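This account rests on a few compounds, and the source may have more. Where it says the series, first, only, none or still open, it means among the compounds named here.

Of the compounds shown here, three built on a shared core have been measured in a functional assay on HeLa cells (Homo sapiens) for antiproliferative activity, read by MTT assay, with a stated time of 48 h; a lower number here means a stronger inhibitor, a higher number a weaker inhibitor. Compound 1 `O=Cc1cn(-c2ccccc2)nc1-c1ccc(Cl)cc1` gives 15500 nM. Compound 2 `Fc1ccc(-c2nn(-c3ccccc3)cc2-c2nc3ccccc3[nH]2)cc1` gives 2330 nM in this assay, and compound 3 `Clc1ccc(-c2nn(-c3ccccc3)cc2-c2nc3ccccc3[nH]2)cc1` gives 1650 nM. Compound 3 therefore stands at the lowest of the three numbers, although compound 2 lies within the usual scatter of it. The two measured steps differ in size: a 9.4-fold lower number from compound 1 to compound 3 (0.97 log units; beyond the scatter), a modest step, whereas a 1.4-fold lower number from compound 2 to compound 3 (0.15 log units; within the scatter), so compound 2 and compound 3 cannot be ordered.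

Compound 4 `O=C(OCc1ccccc1)c1ccc2[nH]c(-c3cn(-c4ccccc4)nc3-c3ccc(Cl)cc3)nc2c1` differs from compound 3 by benzyloxycarbonyl in place of hydrogen on an aromatic carbon.

Neither measured step bears directly on this change. The step of a 9.4-fold lower number from compound 1 to compound 3 (0.97 log units; beyond the scatter) concerns an exchange at a different aromatic carbon of the core, and a 1.4-fold lower number from compound 2 to compound 3 (0.15 log units; within the scatter) concerns only the halogen exchange. Nothing measured here tells what a benzyloxycarbonyl group at this place does, so the size and direction of the coming step in this assay are open; the author expects a step of at most modest size, with a wide range around it. Compound 4 is expected to give 1500 nM, within 400 nM to 6000 nM. That estimate corresponds to an expected step of a 1.1-fold lower number from compound 3 to compound 4 (0.04 log units; within the scatter).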

Compound 4, half-maximal inhibitory concentration: 8130 nM
For compound 4 the middle estimate is 5.4-fold (0.73 log units) below the measured one; the measured number lies above the stated range.
By their numbers in this assay, from the lowest: compounds 3 and 2 (each within the scatter of the next); then compounds 4 and 1 (each within the scatter of the next).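

In this assay, benzyloxycarbonyl in place of hydrogen on the six-membered aromatic ring of carbon only, part of a fused or bridged system of two rings, gives a 4.9-fold higher number from compound 3 to compound 4 (0.69 log units; beyond the scatter) and so lies beyond the scatter, though the step is modest. For the compounds shown here, this is the first measured change at this position, and it shows that the number responds to substitution here and that this particular group raises it, which neither the halogen exchange nor the exchange of formyl for 1H-benzimidazol-2-yl could show. No measurement given here accounts for the rise, so the step stands as an observation without an explanation.

The compounds shown leave open which part of the benzyloxycarbonyl group goes with the higher number, and whether a carboxylic acid, a methyl ester, a primary amide or an amine on the same aromatic carbon would move the number in the same direction or the opposite one. They also leave open whether the same change made on the fluoro compound 2 would give a step of similar size.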